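A few compounds are considered here, and "the series" means these few. Any claim that something is new, unique, unknown or untested is made for them only; others in the source may bear on it.

Measured compounds:
compound 1 `O=c1cc(-c2ccccc2)oc2ccc(N3COc4ccccc4C3)cc12`, 34%
compound 2 `Cc1cccc2c1OCN(c1ccc3c(=O)cc(-c4ccccc4)oc3c1)C2`, 54.9%
compound 3 `Cc1ccc2c(c1)CN(c1ccc3oc(-c4ccccc4)cc(=O)c3c1)CO2`, 31%

All three were run in a functional assay on MCF7 cells (Homo sapiens) for inhibition, read by MTT assay, with a stated time of 48 h, tested at 15 ug/mL; a higher number here means more inhibition of growth at the concentration tested, a lower number less inhibition of growth. Compound 2 stands highest of the three; compound 1 lies well below it and compound 3 lies further below still, both gaps beyond the scatter. Compound 1 and compound 3 share one core and differ only in hydrogen in place of methyl on an aromatic carbon; the step of a number 3 percentage points higher from compound 3 to compound 1 (within the scatter) is within the scatter, so removing the methyl at that place left growth inhibition essentially unchanged. Compound 2 is built from the same atoms as compound 3 but joined differently; the difference between the two cores is not broken down here.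

Compound 4 `O=c1cc(-c2ccccc2)oc2cc(N3COc4ccccc4C3)ccc12` has not yet been measured in this assay. It derives from compound 2 by hydrogen in place of methyl on an aromatic carbon. This is the same kind of change as that from compound 3 to compound 1, but not the same: there the place was meta to a fused ring and para to a fused ring, whereas here it is ortho to a fused ring and meta to a fused ring. Because a number 3 percentage points higher from compound 3 to compound 1 (within the scatter) was small, the expected step is likewise small, a number 3.9 percentage points lower from compound 2 to compound 4 (within the scatter), with the value of compound 2 as the starting point. Compound 4 is therefore expected to give about 51%, estimated between 38% and 64%.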

Compound 4, percent growth inhibition at one concentration: 3.89%
Estimate against measurement, compound 4: 47.1 percentage points above, outside the stated range (below it).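

In this assay, the step for hydrogen in place of methyl on an aromatic carbon is large on the core of compound 2, a number 51 percentage points lower from compound 2 to compound 4 (beyond the scatter), so the methyl at this place goes with much of the growth inhibition seen for compound 2. The size of this change does not carry from one core to the other in this series: the same change on two cores in this assay, a number 3 percentage points higher (within the scatter) from compound 3 to compound 1 and a number 51 percentage points lower (beyond the scatter) from compound 2 to compound 4, 54 percentage points apart, beyond the scatter of two such steps The two pairs differ in the core and also in where the methyl sits, here ortho to a fused ring and meta to a fused ring, so these two steps cannot separate the effect of the core from that of the place, they give no cause for the gap, and one pair per core supports no general rule.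

Going by these compounds, it remains open whether the large step is specific to methyl or would appear with other groups at this place on the core of compound 2, such as a chlorine atom, a methoxy group, an ethyl chain, an amine or a carboxylic acid. On these data alone, it also remains open how a methyl at other places on either core would behave, which would help to separate the core from the place.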